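Allyloxy in place of methoxy: tolerance on Vero cells

The source may report more compounds than this note shows. Statements on the series, on what has been measured and on what is new or still open speak of the compounds shown alone.

Compound 3 `COc1cccc(-c2nc3c(NC4CCCC4)cccn3c2-c2ccnc(NC3CCCC3)n2)c1` belongs to a trio of close analogues measured in an ADME assay on Vero cells (Chlorocebus sabaeus) for cytotoxicity; a lower number here means that less compound is tolerated, a higher number that more compound is tolerated. In this assay compound 3 reaches only a limit, > 40000 nM, not a number. Compound 2 `c1cc(NC2CCCC2)c2nc(-c3ccc(OCC4CC4)cc3)c(-c3ccnc(NC4CCCC4)n3)n2c1` likewise stops at a limit, > 40000 nM. Compound 1 `COc1ccc(-c2nc3c(NC4CCCC4)cccn3c2-c2ccnc(NC3CCCC3)n2)cc1` stops at a limit as well, > 10000 nM. With every value a limit, the steps a step that the two limits leave unreadable from compound 1 to compound 2, a step that the two limits leave unreadable from compound 1 to compound 3 and a step that the two limits leave unreadable from compound 2 to compound 3 have no readable size; all that is seen is that one value sits at the limit of > 10000 nM in this assay, at which 1 of the 3 values shown sits, and two at the limit of > 40000 nM in this assay, at which 2 of the 3 values shown sit.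

Compound 4 `C=CCOc1cccc(-c2nc3c(NC4CCCC4)cccn3c2-c2ccnc(NC3CCCC3)n2)c1` differs from compound 3 by vinyl in place of hydrogen on a saturated chain carbon bound to an oxygen on an aromatic ring. Among the compounds with values here, no measured step gives a readable size for such a change, yet none of the three compounds, including compound 2 with a cyclopropyl on the same chain carbon, showed a cytotoxic concentration inside the measured window. The step that the limit leaves unreadable from compound 3 to compound 4 is therefore expected to be none beyond the scatter. Compound 4 is estimated at 50000 nM, within 20000 nM to 150000 nM, and is most likely to be reported again only as a limit.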

Compound 4, half-maximal cytotoxic concentration: > 40000 nM
Compound 4 ended at the assay's limit; the forecaster's own chance of this, stated with the estimate: 75%; the middle value lies beyond the limit too.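

In this assay compound 4 gives > 40000 nM, which is a limit and not a number. With compounds 1, 2 and 3 also resting on limits, none of the new steps to compound 4 can be read. The compounds shown leave open the concentration at which any of them becomes cytotoxic, and whether allyloxy in place of methoxy changes it at all.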